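A few compounds are considered here, and "the series" means these few. Any claim that something is new, unique, unknown or untested is made for them only; others in the source may bear on it.

For the measured compounds named here, compound 2 `Cc1ccc(S(=O)(=O)N(C)C(C)C)cc1C#Cc1cc(Cl)ccc1OCC(=O)O` stands, in an assay on CHO cells for displacement of a labelled ligand from prostaglandin D2 receptor 2 (Homo sapiens), read by scintillation counting (on this read-out lower numbers stand for stronger inhibition and higher numbers for weaker inhibition), at 3.8 nM, the second highest of the three numbers measured so far. Its nearest neighbour is compound 1 `C[S+]([O-])c1cccc(C#Cc2cc(Cl)ccc2OCC(=O)O)c1`, which in this assay gives 3.2 nM, a gap that lies within the scatter; furthest away is compound 3 `O=C(O)COc1ccc(Cl)cc1C#Cc1ccccc1`, which gives 108 nM. Compound 4 `Cc1ccc(S(=O)(=O)N(C)C)cc1C#Cc1cc(Cl)ccc1OCC(=O)O` has not yet been measured. It differs from compound 2 in a single place: methyl in place of isopropyl on a sulfonamide nitrogen. Going by the values given here, only one step between measured compounds is available, a 34-fold higher number from compound 1 to compound 3 (1.53 log units; beyond the scatter), and that step concerns a group on an aromatic carbon, not the substituent on the sulfonamide nitrogen, so it says little about trading isopropyl for methyl there. Among the compounds with values here, compound 1 and compound 2 carry quite different groups on the aromatic ring yet give numbers within the scatter of each other, which hints that changes in this part of the molecule need not move the number much, though no single-point step confirms that. With nothing bearing directly on the change, the expectation is a shift no larger than the scatter, in either direction, a 1.2-fold higher number from compound 2 to compound 4 (0.07 log units; within the scatter). For compound 4 the estimate in this assay is therefore 4.5 nM, expected to fall between 1.5 nM and 14 nM.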

Compound 4, inhibition constant: 5 nM
Estimate against measurement, compound 4: 1.1-fold (0.05 log units) below; the range from low to high includes it.
By their numbers in this assay, from the lowest: compounds 1, 2 and 4 (each within the scatter of the next); then compound 3.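

In this assay, for the compounds shown here, the step of a 1.3-fold higher number from compound 2 to compound 4 (0.12 log units; within the scatter) is the first comparison that changes only the substituent on this sulfonamide nitrogen, with methyl taking the place of isopropyl. The step lies within the scatter, so this assay cannot tell the isopropyl(methyl)sulfamoyl group of compound 2 from the dimethylsulfamoyl group of compound 4, and for this pair, trimming the chain on the nitrogen to methyl leaves the reading unresolved from where it started. No measured evidence is at hand to say why the two compounds read alike.

Going by these compounds alone, this single pair covers only two small carbon groups, and the second methyl on the nitrogen is the same in both compounds, so the result cannot be stretched to other substituents. From the compounds shown here alone, whether a longer chain such as butyl, a ring such as cyclopropyl, a chain ending in a carboxylic acid or an amine, or a plain hydrogen on this nitrogen would stay within the scatter remains open.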